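The source may hold more compounds than are shown below. What is called first, only, known or untested is meant among the compounds shown, and "the series" means these compounds.

Measured compounds:
- compound 1 `COc1cc(Cl)cc(-c2nn(-c3cccc(NC(=O)c4ccc(Cl)c(Cl)c4)c3)cc2-c2ccncc2)c1`; in a functional assay on SF-539 cells (Homo sapiens) for inhibition, read by sulforhodamine B assay, with a stated time of 48 h, tested at 10 uM (a higher number here means a weaker effect of the compound at the concentration tested, a lower number a stronger effect), compound 1 gives 74.5%
- compound 2 `COc1cc(Cl)cc(-c2nn(-c3cccc(NC(=O)Nc4ccc(Cl)c(Cl)c4)c3)cc2-c2ccncc2)c1`; in this assay compound 2 gives 21%
- compound 3 `COc1cc(Cl)cc(-c2nn(-c3cccc(NC(=O)Nc4cccc(C(F)(F)F)c4)c3)cc2-c2ccncc2)c1`; in this assay compound 3 gives 17%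

Compound 3 holds the lowest number of the three in this assay; compound 2 sits closest, with the gap a number 4 percentage points lower from compound 2 to compound 3 (within the scatter), while compound 1 is furthest away. Compound 4 `COc1cc(Cl)cc(-c2nn(-c3cccc(NC(=O)c4cccc(C(F)(F)F)c4)c3)cc2-c2ccncc2)c1` is not yet measured. It differs from compound 3 in one place: 3-(trifluoromethyl)phenyl in place of (3-(trifluoromethyl)phenyl)amino on a carbonyl carbon.

For the measured compounds named here, two measured steps bear on this change, both run in the opposite direction on the same carbonyl carbon: a number 53.5 percentage points lower from compound 1 to compound 2 (beyond the scatter) and a number 57.5 percentage points lower from compound 1 to compound 3 (beyond the scatter). Both are large, and the choice of aryl group on the amide-type nitrogen made little difference, as a number 4 percentage points lower from compound 2 to compound 3 (within the scatter) shows. Reversing that change from compound 3 should therefore move the number back up by a step of similar size, and compound 4 is expected to land near compound 1. The estimate for compound 4 in this assay is 70%, within 50% to 90%, which means an expected step of a number 53 percentage points higher from compound 3 to compound 4 (beyond the scatter).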

Compound 4, a percentage reported as activity, at one concentration (the size of the read-out at that concentration, not a potency): 64.2%
Beside the measured number, compound 4's estimate is 5.8 percentage points above it, within the range that was stated.
By their numbers in this assay, from the lowest: compounds 3 and 2 (each within the scatter of the next); then compound 4; then compound 1.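

In this assay, the large effect of the amino link on the carbonyl carbon now appears in both directions: removing it gives a number 47.2 percentage points higher from compound 3 to compound 4 (beyond the scatter), and the step with a different aryl group on each side, a number 43.2 percentage points higher from compound 2 to compound 4 (beyond the scatter), is also large. The change therefore holds for both aryl groups shown, with compound 1 and compound 4 on the high side and compound 2 and compound 3 on the low side. Without the amino link the aryl group also registers, though modestly, at a number 10.3 percentage points lower from compound 1 to compound 4 (beyond the scatter), whereas with the link a number 4 percentage points lower from compound 2 to compound 3 (within the scatter) stays within the scatter.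

No measurement here gives a reason for the effect of the amino link. As far as these compounds go, whether the amide hydrogen is what counts remains open, and a carbamate oxygen or a methylene group in place of the amino nitrogen would test this.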